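The source may hold more compounds than are shown below. What is called first, only, known or untested is meant among the compounds shown, and "the series" means these compounds.

Measured so far:
Compound 1 `CN(C)CCn1cnnc1-c1cc(Oc2ccc(NC(=O)N/N=C/c3cccc(Br)c3)cc2F)ccn1` — 4230 nM
Compound 2 `CN(C)CCn1cnnc1-c1cc(Oc2ccc(NC(=O)N/N=C/c3ccc(Cl)cc3)cc2F)ccn1` — 1870 nM
Compound 3 `CN(C)CCn1cnnc1-c1cc(Oc2ccc(NC(=O)N/N=C/c3c(O)ccc4ccccc34)cc2F)ccn1` — 3250 nM

In an ADME assay on WI-38 cells (Homo sapiens) for cytotoxicity, read by MTT assay, with a stated time of 72 h (a lower number here means a stronger inhibitor, a higher number a weaker inhibitor), compound 1 gives the highest of these three numbers, though compound 3 stands within the scatter of it and only compound 2 lies beyond. Compound 4 `COc1cc(/C=N/NC(=O)Nc2ccc(Oc3ccnc(-c4nncn4CCN(C)C)c3)c(F)c2)ccc1O` differs from compound 1 in one place: 4-hydroxy-3-methoxyphenyl in place of 3-bromophenyl on a carbon with a double bond to nitrogen. Two measured steps swap the same group for another ring: a 2.3-fold lower number from compound 1 to compound 2 (0.35 log units; beyond the scatter) and a 1.3-fold lower number from compound 1 to compound 3 (0.11 log units; within the scatter). One produced a modest drop, the other nothing beyond the scatter, so this position appears to tolerate such swaps without large shifts. For compound 4 a small downward step is therefore expected, a 1.4-fold lower number from compound 1 to compound 4 (0.15 log units; within the scatter). The estimate for compound 4 is 3000 nM, expected to fall between 1200 nM and 7500 nM.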

Compound 4, half-maximal inhibitory concentration: 5320 nM
The estimate for compound 4 lay 1.8-fold (0.25 log units) below the measured number; the measured number falls inside the stated range.
By their numbers in this assay, from the lowest: compounds 2, 3, 1 and 4 (each within the scatter of the next, the first and the last beyond it).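

In this assay, the 4-hydroxy-3-methoxyphenyl ring brings two oxygens to this carbon, yet the number stays within the scatter of two earlier compounds: a 1.3-fold higher number from compound 1 to compound 4 (0.10 log units; within the scatter) and a 1.6-fold higher number from compound 3 to compound 4 (0.21 log units; within the scatter). Within the data shown here, the one step beyond the scatter is a 2.8-fold higher number from compound 2 to compound 4 (0.45 log units; beyond the scatter), so the 4-chlorophenyl ring of compound 2 now stands apart from compound 4 as well as from compound 1. No available evidence explains this difference. Still open, on these data alone, is how a ring carrying an amine or a carboxylic acid would behave here, and whether a simple alkyl chain could replace the ring.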